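Acetamide to nicotinamide on the shared core

This account rests on a few compounds, and the source may have more. Where it says the series, first, only, none or still open, it means among the compounds named here.

Compound 1 `Cn1cc(-c2cnc3ccc(NC(=O)C4CC4)nc3c2)cn1` gives in a functional assay on A549 cells (Homo sapiens) for antiproliferative activity, read by MTT assay, with a stated time of 48 h (on this read-out lower numbers stand for stronger inhibition and higher numbers for weaker inhibition), only a limit, > 50000 nM. Compound 2 `CC(=O)Nc1nccc2ncc(-c3cnn(C)c3)cc12` likewise gives only a limit, > 50000 nM. Among the measured compounds shown here, compound 2 therefore stands nowhere above the other value; both readings sit at the limit of > 50000 nM in this assay, at which 2 of the 2 values shown sit, so no measured step exists. Compound 3 `Cn1cc(-c2cnc3ccnc(NC(=O)c4cccnc4)c3c2)cn1` differs from compound 2 by pyridin-3-yl in place of methyl on a carbonyl carbon. With both anchors at the limit, compound 3 is expected to remain weak, and a step of an at least 1.2-fold lower number from compound 2 to compound 3 (0.09 log units; that floor lies within the scatter) beyond the scatter is not expected. Compound 3 is estimated at 40000 nM, between 8000 nM and 150000 nM.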

Compound 3, half-maximal inhibitory concentration: > 50000 nM
Compound 3 was reported as a limit (the forecaster's own chance of this, stated with the estimate: 60%); middle value at least 1.2-fold (0.09 log units) away from the limit.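

No step can be read from compound 2 to compound 3, since both give only a limit in this assay: the limit of > 50000 nM in this assay, at which 3 of the 3 values shown sit.

The compounds shown leave open whether pyridin-3-yl in place of methyl on a carbonyl carbon changes the read-out in this assay at all.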